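Nitrophenyl for hydroxymethoxyphenyl on the shared core

The compounds below may be only part of what the source reports. "The series", "measured", "known", "first", "only" and "open" are said of these compounds alone.

Two compounds of the series have a number in an assay for inhibition of protein disulfide-isomerase (Homo sapiens), with a stated time of 1 h; a lower number here means a stronger inhibitor, a higher number a weaker inhibitor. Compound 1 `Oc1c(C(c2ccc(F)cc2)N2CCCCC2)ccc2scnc12` gives 570 nM. Going by the values given here, compound 2 `COc1ccc(C(Nc2cc(C)ccn2)c2ccc3cccnc3c2O)cc1O` gives 150 nM, the lower of the two numbers; the gap to compound 1 lies beyond the usual scatter, and the two structures differ in more than one place, so no single step connects them. Compound 3 `Cc1ccnc(NC(c2ccc([N+](=O)[O-])cc2)c2ccc3cccnc3c2O)c1` is not yet measured. Compound 3 differs from compound 2 in one place: 4-nitrophenyl in place of 3-hydroxy-4-methoxyphenyl on a saturated chain carbon bound to an aromatic carbon and a nitrogen on an aromatic ring. Among the compounds with values here, no measured pair shows the effect of this change, so the expectation rests on compound 2 alone. A step toward a somewhat higher number is expected, with the direction not secure. Compound 3 is estimated at 400 nM in this assay, with a range from 120 nM to 1500 nM. The step this estimate means is expected to be a 2.7-fold higher number from compound 2 to compound 3 (0.43 log units; beyond the scatter).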

Compound 3, half-maximal inhibitory concentration: 530 nM
Compound 3: middle estimate off by 1.3-fold (0.12 log units), on the low side, and the stated range covers the measured number.
By their numbers in this assay, from the lowest: compound 2; then compounds 3 and 1 (each within the scatter of the next).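

In this assay the series now has its first direct reading at this position, the saturated chain carbon bound to an aromatic carbon and a nitrogen on an aromatic ring: 4-nitrophenyl in place of 3-hydroxy-4-methoxyphenyl gives a 3.5-fold higher number from compound 2 to compound 3 (0.55 log units; beyond the scatter) and counts as a modest step. The position is therefore sensitive to this exchange, although both groups have 9 heavy atoms and 2 hydrogen-bond acceptors, while the hydrogen-bond donors go from 1 to 0. Nothing available ties the step to any one difference between the two groups.

Still open, going by these compounds, is whether the step follows from losing the hydroxy group, losing the methoxy group or gaining the nitro group. Also open, on these data alone, is where an unsubstituted phenyl, a 4-methoxyphenyl or a 4-aminophenyl would fall at the same place.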